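Swapping the aryl group on the hydrazone carbon

The source may hold more compounds than are shown below. What is called first, only, known or untested is meant among the compounds shown, and "the series" means these compounds.

Compound 1 `CN(C)CCn1cnnc1-c1cc(Oc2ccc(NC(=O)N/N=C/c3ccc(O)c(F)c3)cc2F)ccn1`: 1970 nM
Compound 2 `CN(C)CCn1cnnc1-c1cc(Oc2ccc(NC(=O)N/N=C/c3c[nH]c4ccccc34)cc2F)ccn1`: 790 nM
Compound 3 `CN(C)CCn1cnnc1-c1cc(Oc2ccc(NC(=O)N/N=C/c3ccc(F)cc3)cc2F)ccn1`: 1030 nM

These three compounds share one core and differ only in the group on a carbon with a double bond to nitrogen; all were tested in a functional assay on MKN-45 cells (Homo sapiens) for cytotoxicity, read by MTT assay, with a stated time of 72 h; a lower number here means a stronger inhibitor, a higher number a weaker inhibitor. Compound 3 gives 1030 nM, the second highest of the three numbers, and both of its neighbours lie close: a 1.3-fold higher number from compound 2 to compound 3 (0.12 log units; within the scatter), and a 1.9-fold lower number from compound 1 to compound 3 (0.28 log units; within the scatter).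

Compound 4 `CN(C)CCn1cnnc1-c1cc(Oc2ccc(NC(=O)N/N=C/c3c(Cl)cccc3Cl)cc2F)ccn1` has not yet been measured. Its change from compound 3: 2,6-dichlorophenyl in place of 4-fluorophenyl on a carbon with a double bond to nitrogen. Among the measured compounds shown here, the two earlier changes at this same carbon, a 1.9-fold lower number from compound 1 to compound 3 (0.28 log units; within the scatter) and a 1.3-fold higher number from compound 2 to compound 3 (0.12 log units; within the scatter), stayed within the scatter, and the only step beyond it, a 2.5-fold lower number from compound 1 to compound 2 (0.40 log units; beyond the scatter), was modest. So no step beyond the scatter is expected: a 1.0-fold lower number from compound 3 to compound 4 (0.01 log units; within the scatter). Compound 4 is estimated at 1000 nM, expected between 400 nM and 2500 nM.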

Compound 4, half-maximal inhibitory concentration: 160 nM
Beside the measured number, compound 4's estimate is 6.3-fold (0.80 log units) above it, outside the stated range (below it).
By their numbers in this assay, from the lowest: compound 4; then compounds 2, 3 and 1 (each within the scatter of the next, the first and the last beyond it).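

Earlier swaps at this carbon gave at most a modest step, but 2,6-dichlorophenyl gives a much lower number than each of the other groups (a 6.4-fold lower number from compound 3 to compound 4 (0.81 log units; beyond the scatter); a 4.9-fold lower number from compound 2 to compound 4 (0.69 log units; beyond the scatter); a 12-fold lower number from compound 1 to compound 4 (1.09 log units; beyond the scatter)). The number at this position can therefore move much further than the first three compounds suggested, and compound 4 lies beyond the scatter of all three. Nothing available explains this gain.

From the compounds shown here alone, it remains open whether both chlorines are needed, since a phenyl ring carrying a single chlorine could behave differently. Going by these compounds, it is also open whether two methyl groups in place of the two chlorines would give a similar number.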